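Capping the Amine: From Compound 2 Toward Compound 3

The source may hold more compounds than are shown below. What is called first, only, known or untested is meant among the compounds shown, and "the series" means these compounds.

Of the compounds shown here, two have been measured in an assay for inhibition of protein deacetylase HDAC6 (Homo sapiens); on this read-out lower numbers stand for stronger inhibition and higher numbers for weaker inhibition. Compound 1 `NS(=O)(=O)NCCCC[C@H](NC(=O)OCc1ccccc1)C(=O)Nc1nc2ccccc2s1` gives 190 nM. Compound 2 `N[C@@H](CCCCNS(N)(=O)=O)C(=O)Nc1nc(-c2ccccc2)cs1` gives 1100 nM, the higher of the two numbers, and its gap to compound 1 lies beyond the usual scatter. Among the compounds with values here, compound 1 and compound 2 differ in more than one place, so no single structural step joins them.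

Compound 3 `NS(=O)(=O)NCCCC[C@H](NC(=O)OCc1ccc(Cl)cc1)C(=O)Nc1nc(-c2ccccc2)cs1` has not yet been measured. It arises from compound 2 by one change: ((4-chlorobenzyl)oxy)carbonyl in place of hydrogen on an amine nitrogen. The free amine of compound 2 thereby becomes a carbamate, a step that is not present in pure form among the measured pair.

Because compound 1 gives 190 nM with its amine capped by a related benzyloxycarbonyl group, whereas compound 2 gives 1100 nM with a free amine, compound 3 is expected to return a lower number than compound 2. This expectation corresponds to a step of a 4.4-fold lower number from compound 2 to compound 3 (0.64 log units; beyond the scatter). The estimate for compound 3 is 250 nM, with a range from 80 nM to 800 nM.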

Compound 3, half-maximal inhibitory concentration: 530 nM
Estimate against measurement, compound 3: 2.1-fold (0.33 log units) below, and the stated range covers the measured number.
By their numbers in this assay, from the lowest: compound 1; then compound 3; then compound 2.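

On this assay, replacing hydrogen on the amine nitrogen with ((4-chlorobenzyl)oxy)carbonyl gives a 2.1-fold lower number from compound 2 to compound 3 (0.32 log units; beyond the scatter), a modest step but one beyond the scatter. Within the data shown here, this is the first effect of a single change that can be read at this position, since the earlier pair differ in more than one place and could only hint that a capped amine might go with a lower number. It shows that the free amine can be turned into a carbamate carrying a whole extra aromatic ring without any loss of inhibition, and with a small gain, though nothing available accounts for that gain.

On these data alone, the role of the chlorine stays open, as compound 1 and compound 3 differ in more than one place and their numbers cannot be read as a single step. As far as these compounds go, it also remains open how a plain benzyloxycarbonyl group, a smaller acetyl group or a fluorine in place of the chlorine would compare on this same core.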